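The source may report more compounds than this note shows. Statements on the series, on what has been measured and on what is new or still open speak of the compounds shown alone.

Of the compounds shown here, two of a shared core have been measured in a functional assay on HCC 2998 cells (Homo sapiens) for antiproliferative activity; a lower number here means a stronger inhibitor of growth, a higher number a weaker inhibitor of growth. Compound 1 `COc1ccc(-c2nc3cc(F)ccc3s2)cc1` gives 12400 nM in this assay. Among the compounds with values here, compound 2 `COc1ccc(-c2nc3cc(F)ccc3s2)cc1Br` gives 3450 nM in this assay, and the step of a 3.6-fold lower number from compound 1 to compound 2 (0.56 log units; beyond the scatter) shows it stands as the lower of the two numbers, with compound 1 as its only neighbour. Compound 3 `COc1ccc(-c2nc3cc(F)ccc3s2)cc1O` has not yet been measured; its change from compound 2 is hydroxy in place of bromo on an aromatic carbon. Within the data shown here, only one measured step bears on this position: the bromo added in a 3.6-fold lower number from compound 1 to compound 2 (0.56 log units; beyond the scatter), a modest gain, but a hydroxy is not a bromo, so that step is a weak guide. A hydroxy at this carbon is expected to land somewhere between the two measured numbers, nearer to compound 1. The estimate for compound 3 is 7000 nM, within 2500 nM to 20000 nM, which would mean a step of a 2.0-fold higher number from compound 2 to compound 3 (0.31 log units; beyond the scatter).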

Compound 3, concentration for 50% growth inhibition: 7600 nM
Compound 3: the middle estimate sits 1.1-fold (0.04 log units) below what was measured; the measured number falls inside the stated range.
By their numbers in this assay, from the lowest: compound 2; then compounds 3 and 1 (each within the scatter of the next).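

In this assay, swapping bromo for hydroxy at this carbon gives a 2.2-fold higher number from compound 2 to compound 3 (0.34 log units; beyond the scatter), so the benefit seen with bromo does not carry over to every replacement for hydrogen here. Hydroxy in place of hydrogen gives a 1.6-fold lower number from compound 1 to compound 3 (0.21 log units; within the scatter), which means compound 3 cannot be told apart from compound 1, and among these three compounds only bromo gives a clear separation from hydrogen. The data offer no measurement that explains the difference between bromo and hydroxy.

From the compounds shown here alone, it remains open whether another halogen, such as chloro or iodo, would behave like bromo at this carbon. An amine or a methyl group here could also fall on either side, so three compounds give no general trend for this position.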